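Amide chain notes: from compound 2 to compound 3

The source may report more compounds than this note shows. Statements on the series, on what has been measured and on what is new or still open speak of the compounds shown alone.

Compound 1 `CCCC(=O)Nc1nc2ccc(Cl)cc2s1`: > 50000 nM (a limit)
Compound 2 `O=C(CC1CC1)Nc1nc2ccc(Cl)cc2s1`: > 50000 nM (a limit)

Both entries come from an ADME assay on H9c2 cells (Rattus norvegicus) for cytotoxicity; on this read-out higher numbers stand for weaker inhibition and lower numbers for stronger inhibition. For the measured compounds named here, compound 2 stands only at its limit of > 50000 nM, and the series so far reads as the limit of > 50000 nM in this assay, at which 2 of the 2 values shown sit. Compound 3 `O=C(CCO)Nc1nc2ccc(Cl)cc2s1` differs from it by hydroxymethyl in place of cyclopropyl on a saturated chain carbon bound to a carbonyl carbon. Going by the values given here, the only measured step that bears on this is a step that the two limits leave unreadable from compound 1 to compound 2. No size or direction can be read from it, so no shift beyond the scatter is expected in this assay. The expected change is a number no higher from compound 2 to compound 3 (the limit leaves the size open). Compound 3 is estimated at 50000 nM, with an expected range of 25000 nM to 100000 nM.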

Compound 3, half-maximal inhibitory concentration: > 50000 nM
Compound 3: no number, only a limit (the forecaster's own chance of this, stated with the estimate: 85%); the middle value lies on the limit itself.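

No step can be read among compound 1, compound 2 and compound 3 in this assay, each value being a limit and not a number: the limit of > 50000 nM in this assay, at which 3 of the 3 values shown sit.

The compounds shown leave open whether these amide chains differ at all in this assay.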